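A few compounds are considered here, and "the series" means these few. Any claim that something is new, unique, unknown or untested is made for them only; others in the source may bear on it.

Three compounds share one core and differ only in the phenyl group carried on an aromatic nitrogen. In a functional assay on A549 cells (Homo sapiens) for antiproliferative activity, read by MTT assay, with a stated time of 48 h (on this read-out higher numbers stand for weaker inhibition and lower numbers for stronger inhibition), compound 1 `CCc1ccccc1-n1nncc1CN1C(=O)C2(C(C#N)=C(N)Oc3c(N)cc4nc5ccccc5nc4c32)c2ccccc21` gives 24600 nM. Compound 2 `N#CC1=C(N)Oc2c(N)cc3nc4ccccc4nc3c2C12C(=O)N(Cc1cnnn1-c1cccc(Br)c1)c1ccccc12` gives 18900 nM, a step of a 1.3-fold lower number from compound 1 to compound 2 (0.11 log units; within the scatter). Compound 3 `Cc1ccc(-n2nncc2CN2C(=O)C3(C(C#N)=C(N)Oc4c(N)cc5nc6ccccc6nc5c43)c3ccccc32)cc1C` reaches only the limit > 50000 nM in this assay, which is a limit and not a measured number. The steps of an at least 2.0-fold higher number from compound 1 to compound 3 (0.30 log units; that floor lies within the scatter) and an at least 2.6-fold higher number from compound 2 to compound 3 (0.42 log units; beyond the scatter) place compound 3 at the weak end of the values shown, as marked by the limit of > 50000 nM in this assay, at which 1 of the 3 values shown sits. Compound 4 `Cc1ccc(-n2nncc2CN2C(=O)C3(C(C#N)=C(N)Oc4c(N)cc5nc6ccccc6nc5c43)c3ccccc32)cc1Cl` differs from compound 3 by chloro in place of methyl on an aromatic carbon. Compound 2 also carries a halogen on this phenyl and gives 18900 nM, with the step of an at least 2.6-fold higher number from compound 2 to compound 3 (0.42 log units; beyond the scatter) beyond the scatter. Compound 4 is therefore expected at 35000 nM, between 15000 nM and 80000 nM, an expected step of an at least 1.4-fold lower number from compound 3 to compound 4 (0.15 log units; that floor lies within the scatter).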

Compound 4, half-maximal inhibitory concentration: 11800 nM
Compound 4: middle estimate off by 3.0-fold (0.47 log units), on the high side; measured number outside the range, below it.
By their numbers in this assay, from the lowest: compounds 4, 2 and 1 (each within the scatter of the next, the first and the last beyond it). At a limit, above all of these: compound 3.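

In this assay, chloro in place of methyl on an aromatic carbon is enough on its own to give a step beyond the scatter (an at least 4.2-fold lower number from compound 3 to compound 4 (0.62 log units; beyond the scatter)), so this single position on the phenyl affects the read-out. Compound 3 carries a limit and not a number, so that step is only a floor: the limit of > 50000 nM in this assay, at which 1 of the 4 values shown sits. The 3-chloro-4-methylphenyl group also gives a modest step (a 2.1-fold lower number from compound 1 to compound 4 (0.32 log units; beyond the scatter)), whereas a 1.6-fold lower number from compound 2 to compound 4 (0.20 log units; within the scatter) stays within the scatter.

Open, on these data alone, is how fluoro, methoxy or an amine at this position would compare, and whether the chloro step holds on a phenyl without the remaining methyl group.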